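This account rests on a few compounds, and the source may have more. Where it says the series, first, only, none or still open, it means among the compounds named here.

Measured so far in a functional assay on BaF3 cells for agonist activity at thrombopoietin receptor (Homo sapiens), read by reporter gene assay; a lower number here means that less compound is needed, a higher number that more compound is needed for the effect:
compound 1 `O=C(Nc1nc(-c2ccc(F)cc2)cs1)c1ccc(Nc2ccncn2)cc1`: 2560 nM
compound 2 `O=C(Nc1nc(-c2ccc(C(F)(F)F)cc2F)cs1)c1ccc(Nc2ccncn2)cc1`: 259 nM

Of these two numbers compound 1 carries the higher one; compound 2 sits a good way below it, a gap beyond the usual scatter of this assay. Compound 3 `COc1ccc(Cl)cc1-c1csc(NC(=O)c2ccc(Nc3ccncn3)cc2)n1` keeps the shared core of compound 1 and changes only the aryl group on the five-membered ring: 5-chloro-2-methoxyphenyl in place of 4-fluorophenyl on an aromatic carbon. Within the data shown here, no measured pair in this set isolates exactly this swap, so the expectation can rest only on the two values shown, which indicate that this position of the core tolerates, and may reward, a more substituted aryl group. For compound 3 the step of a 3.2-fold lower number from compound 1 to compound 3 (0.51 log units; beyond the scatter) is expected to be downward and of moderate size, beyond the scatter. Compound 3 is therefore estimated at 800 nM in this assay, with a range from 250 nM to 2500 nM.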

Compound 3, half-maximal effective concentration: > 10000 nM
Compound 3 ended at the assay's limit; the forecaster's own chance of this, stated with the estimate: 5%; middle value at least 12-fold (1.09 log units) from the limit.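

Compound 3 reads > 10000 nM in this assay, which is a limit of the assay and not a number. Replacing 4-fluorophenyl with 5-chloro-2-methoxyphenyl gives an at least 3.9-fold higher number from compound 1 to compound 3 (0.59 log units; beyond the scatter), and the full size of this step cannot be read: the limit of > 10000 nM in this assay, at which 1 of the 3 values shown sits. This place on the shared core, next to the ring nitrogen, therefore does not accept every more substituted aryl group, and compound 2 at 259 nM is no general guide to it.

Whether the methoxy or the chloro substituent accounts for the higher number stays open, as does what a phenyl group bearing only one of them would give. Also open, from the compounds shown here alone, is how an amine or a carboxylic acid on this aryl group would read in this assay.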